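Compound 3 to compound 4: benzyl to 4-methoxybenzyl

A few compounds are considered here, and "the series" means these few. Any claim that something is new, unique, unknown or untested is made for them only; others in the source may bear on it.

In an ADME assay on J774.A1 cells (Mus musculus) for cytotoxicity, read by MTT assay, with a stated time of 48 h (on this read-out lower numbers stand for higher toxicity in this test and higher numbers for lower toxicity in this test), compound 1 (`COC(=O)c1c([N+](=O)[O-])noc1-c1ccc(Cl)cc1Cl`) gives 19700 nM as its reading. Compound 2 (`COc1ccc(CNC(=O)c2c([N+](=O)[O-])noc2-c2ccc([N+](=O)[O-])cc2)cc1`) gives 69600 nM and compound 3 (`COC(=O)c1c(NCc2ccccc2)noc1-c1ccc(Cl)cc1Cl`) gives 54200 nM on the same scale. Compound 3 is level with compound 2 within the scatter and stands clearly higher than compound 1 in this small set.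

The next compound is compound 4 (`COC(=O)c1c(NCc2ccc(OC)cc2)noc1-c1ccc(Cl)cc1Cl`), which has methoxy in place of hydrogen on an aromatic carbon, para to a large group (methoxy in place of hydrogen on an aromatic carbon). Going by the values given here, the only measured step in the set is a 2.8-fold higher number from compound 1 to compound 3 (0.44 log units; beyond the scatter) for benzylamino in place of nitro on an aromatic carbon. That step is modest and concerns a different change, so it gives no direct guide here. Compound 3 differs from compound 2 in several places, and compound 2 at 69600 nM carries a 4-methoxybenzyl group without isolating the effect of this change. Among the compounds with values here, with no measured step testing methoxy here, no shift beyond the scatter is expected in this assay in either direction. The expected size of the change is a 1.1-fold lower number from compound 3 to compound 4 (0.04 log units; within the scatter) on this estimate. Compound 4 is estimated at 50000 nM with an expected range of 24000 nM to 100000 nM for its reading.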

Compound 4, half-maximal cytotoxic concentration: 34700 nM
The estimate for compound 4 lay 1.4-fold (0.16 log units) above the measured number; measured number inside the range.
By their numbers in this assay, from the lowest: compounds 1, 4, 3 and 2 (each within the scatter of the next, the first and the last beyond it).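

Methoxy in place of hydrogen on an aromatic carbon, para to a large group, gives the first measured step at this place in this assay (a 1.6-fold lower number from compound 3 to compound 4 (0.19 log units; within the scatter)), and that step stays within the scatter, so this read-out does not separate the benzyl and 4-methoxybenzyl compounds. The earlier step (a 2.8-fold higher number from compound 1 to compound 3 (0.44 log units; beyond the scatter)) replaced nitro with benzylamino and lay beyond the scatter, so the series now holds one change with a readable shift and one, further out on the benzyl group, without one. No measured property or other supporting data bears on this result, and the data offer no explanation of it.

A single group at this place leaves open whether the flat reading extends to other groups, such as an amine or a carboxylic acid in place of methoxy on the same carbon. As far as these compounds go, it is also open whether a longer chain in place of benzyl, or a 4-methoxybenzyl group on compounds differing elsewhere in the core, would move the number beyond the scatter.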